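A few compounds are considered here, and "the series" means these few. Any claim that something is new, unique, unknown or untested is made for them only; others in the source may bear on it.

Compound 2 `CC(C)N(Cc1cccc(OCCCCCC(=O)O)c1)C(=O)c1ccc(-c2ccc3cc[nH]c3c2)cc1` was examined in an ADME assay on HepG2 cells (Homo sapiens) for cytotoxicity, read by CellTiter-Glo and resazurin assay, with a stated time of 72 h; a lower number here means that less compound is needed, a higher number that more compound is needed for the effect. Compound 2 gives only a limit there, > 26000 nM, and not a number. Its result sits at the limit of > 26000 nM in this assay, at which 1 of the 2 values shown sits. Compound 1 `CC(C)N(Cc1cccc(OCCCCCC(=O)O)c1)C(=O)c1ccc(-c2cccc(Oc3ccccc3)c2)cc1` is the other member of this small set. In this assay compound 1 likewise reaches only a limit, > 18700 nM. Its result sits at the limit of > 18700 nM in this assay, at which 1 of the 2 values shown sits. Among the measured compounds shown here, because both results are limits, no step between measured compounds can be computed, and compound 2 stands at the edge of what this assay resolves rather than at a defined point. Compound 3 `CC(C)N(Cc1cccc(OCCCCCC(=O)O)c1)C(=O)c1ccc(-c2cccc(S(C)(=O)=O)c2)cc1` has not yet been measured. It differs from compound 2 in one place: 3-(methylsulfonyl)phenyl in place of 1H-indol-6-yl on an aromatic carbon. For the measured compounds named here, no measured step sets the size of this change, so the expectation rests on the two limits alone. Compound 3 is expected to give 30000 nM in this assay, with a range from 15000 nM to 60000 nM, and most likely again only a limit. The step that the limit leaves unreadable from compound 2 to compound 3 implied by this estimate is expected to stay within the scatter, with no direction beyond it.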

Compound 3, half-maximal effective concentration: > 26000 nM
Compound 3 gave a limit, no number; the forecaster's own chance of this, stated with the estimate: 85%; the middle value is on the limit's open side.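

Compound 3 gives only a limit in this assay and no number: the limit of > 26000 nM in this assay, at which 2 of the 3 values shown sit. As compound 1 and compound 2 also give only limits, neither the step from compound 2 to compound 3 nor the step from compound 1 to compound 3 can be read. The compounds shown leave open where any of the three reaches its half-maximal effect in this assay and whether the exchanged groups make any difference there.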